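Cyclohexyl for cyclopropyl on the ring nitrogen of compound 1

The compounds below may be only part of what the source reports. "The series", "measured", "known", "first", "only" and "open" are said of these compounds alone.

Compound 1 `O=c1c(S(=O)(=O)c2ccc(F)cc2F)cc2cnc(Nc3ccc4[nH]ccc4c3)nc2n1C1CC1` is the reference point of this small set. In a functional assay on DU-145 cells (Homo sapiens) for inhibition, read by trypan blue exclusion, with a stated time of 72 h (a lower number here means a stronger inhibitor, a higher number a weaker inhibitor), compound 1 gives 500 nM, the lowest of the three numbers measured. Compound 2 `Cn1c(=O)c(S(=O)(=O)c2ccc(F)cc2)cc2cnc(Nc3ccc4[nH]cnc4c3)nc21` gives 10000 nM in this assay, and compound 3 `Cn1c(=O)c(S(=O)(=O)c2ccc(F)cc2F)cc2cnc(NCc3ccc4[nH]ccc4c3)nc21` gives 100000 nM; both gaps to compound 1 lie beyond the scatter, so compound 1 is the strongest inhibitor measured here. For the measured compounds named here, no pair among the three compounds differs in one place only, so the separate changes in substituent, linker and fused ring cannot be pulled apart from these data.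

Compound 4 `O=c1c(S(=O)(=O)c2ccc(F)cc2F)cc2cnc(Nc3ccc4[nH]ccc4c3)nc2n1C1CCCCC1` has not been measured. It differs from compound 1 only in this way: cyclohexyl in place of cyclopropyl on an aromatic nitrogen. Nothing measured in the set speaks to a change at this position, so no direction can be drawn from the data. The step from compound 1 to compound 4 in this assay is expected to be a 1.8-fold higher number from compound 1 to compound 4 (0.26 log units; within the scatter), near or only slightly beyond the scatter, with a weaker inhibitor somewhat more likely than a stronger one. Compound 4 is accordingly estimated at 900 nM, within a range of 200 nM to 4000 nM.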

Compound 4, half-maximal inhibitory concentration: 10000 nM
Compound 4: middle estimate off by 11-fold (1.05 log units), on the low side; measured number outside the range, above it.
By their numbers in this assay, from the lowest: compound 1; then compounds 2 and 4 (each within the scatter of the next); then compound 3.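

The group on the aromatic nitrogen is a sensitive position in this assay: cyclohexyl in place of cyclopropyl gives a 20-fold higher number from compound 1 to compound 4 (1.30 log units; beyond the scatter) and so a weaker inhibitor. For the compounds shown here, this is the first change made in one place only, and it shows that this position alone, with the rest of the structure held fixed, can move the number well beyond the scatter. The data offer no measured property or other evidence that accounts for the step.

Two rings cannot show whether the number rises gradually with ring size or sharply at some size, which cyclobutyl or cyclopentyl on the same nitrogen would settle. Also open, from the compounds shown here alone, is whether an open chain such as isopropyl follows cyclopropyl or cyclohexyl, and the methyl of compound 2 and compound 3 cannot answer this, as both differ from compound 1 elsewhere too.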